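The compounds below may be only part of what the source reports. "The series", "measured", "known", "first", "only" and "open" are said of these compounds alone.

Measured in a functional assay on RS4-11 cells (Homo sapiens) for inhibition, read by CCK-8 assay, with a stated time of 48 h, tested at 20 uM; on this read-out lower numbers stand for less inhibition of growth and higher numbers for more inhibition of growth at the one concentration tested:
compound 1 `COc1ccc(S(=O)(=O)Oc2ccccc2/C=C(\C#N)C(=O)Nc2nnc(-c3cccs3)s2)cc1`: 76%
compound 2 `N#C/C(=C\c1ccccc1OS(=O)(=O)c1ccc([N+](=O)[O-])cc1)C(=O)Nc1nnc(-c2cccs2)s1`: 40%
compound 3 `Cc1ccc(S(=O)(=O)Oc2ccccc2/C=C(\C#N)C(=O)Nc2nnc(Cc3ccccc3)s2)cc1`: 69%

Compound 2 stands lowest of these three numbers. Compound 4 `N#C/C(=C\c1ccccc1OS(=O)(=O)c1ccc([N+](=O)[O-])cc1)C(=O)Nc1nnc(Cc2ccc(F)cc2)s1` keeps its nitro group but differs elsewhere: 4-fluorobenzyl in place of thiophen-2-yl on an aromatic carbon, with 4-fluorobenzyl in place of thiophen-2-yl on an aromatic carbon. Among the measured compounds shown here, the one measured step is a number 36 percentage points lower from compound 1 to compound 2 (beyond the scatter). For the measured compounds named here, it is large, but it concerns nitro in place of methoxy, not this change, so no measured step isolates the new group. Compound 1, with thiophen-2-yl, gives 76%, and compound 3, with benzyl and methyl, gives 69%. These two values lie within the usual scatter of each other, though they differ in two places. The expected result is a number 5 percentage points higher from compound 2 to compound 4 (within the scatter), no step beyond the scatter in this assay. For compound 4 the estimate is 45%, with an expected range from 25% to 65%.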

Compound 4, percent growth inhibition at one concentration: 55%
Compound 4: the middle estimate sits 10 percentage points below what was measured; measured number inside the range.
By their numbers in this assay, from the lowest: compound 2; then compound 4; then compounds 3 and 1 (each within the scatter of the next).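

Replacing thiophen-2-yl with 4-fluorobenzyl gives a number 15 percentage points higher from compound 2 to compound 4 (beyond the scatter) in this assay, the first view of this position on its own, with the nitro group held in place. So growth inhibition responds to what sits on this aromatic carbon, and a six-membered aromatic ring of carbon only is accepted there. No data here explain the rise.

Going by these compounds, it remains open whether the fluorine or the benzyl part carries this gain, and whether the same swap would help with methoxy in place of nitro. On these data alone, how an amine or a longer chain would score at this position is also open.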